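This account rests on a few compounds, and the source may have more. Where it says the series, first, only, none or still open, it means among the compounds named here.

Compound 1 `COc1ccc(OC)c(/C=C/C(=O)C(=Cc2cc(OC)c(O)c(OC)c2)C(=O)/C=C/c2cc(OC)ccc2OC)c1` is a curcumin-like bis-enone carrying a 4-hydroxy-3,5-dimethoxyphenyl on the central chain carbon. In a functional assay on SW480 cells (Homo sapiens) for antiproliferative activity, read by sulforhodamine B assay, with a stated time of 48 h (on this read-out higher numbers stand for weaker inhibition and lower numbers for stronger inhibition), compound 1 gives 500 nM. Compound 2 `COc1ccc(OC)c(/C=C/C(=O)C(=Cc2ccc(OC)c(O)c2)C(=O)/C=C/c2cc(OC)ccc2OC)c1` keeps the same outer aryl groups but differs at the centre: 3-hydroxy-4-methoxyphenyl in place of 4-hydroxy-3,5-dimethoxyphenyl on a double-bonded chain carbon bound to a double-bonded chain carbon. In this assay compound 2 gives 1120 nM, and the step of a 2.2-fold higher number from compound 1 to compound 2 (0.35 log units; beyond the scatter) is a modest loss of potency.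

Compound 3 `COc1ccc(/C=C/C(=O)C(=Cc2cc(OC)c(O)c(OC)c2)C(=O)/C=C/c2ccc(OC)cc2OC)c(OC)c1` has the same atoms as compound 1, joined differently in the outer aryl groups; the difference between the two cores is not broken down here. In this assay compound 3 gives 850 nM.

Compound 4 `COc1ccc(/C=C/C(=O)C(=Cc2ccc(OC)c(O)c2)C(=O)/C=C/c2ccc(OC)cc2OC)c(OC)c1` stands to compound 3 as compound 2 stands to compound 1, by the same change: 3-hydroxy-4-methoxyphenyl in place of 4-hydroxy-3,5-dimethoxyphenyl on a double-bonded chain carbon bound to a double-bonded chain carbon. It has not yet been measured in this assay. Among the compounds with values here, since the first instance of this change produced a 2.2-fold higher number from compound 1 to compound 2 (0.35 log units; beyond the scatter), a step of similar size is expected here, a 2.1-fold higher number from compound 3 to compound 4 (0.33 log units; beyond the scatter), resting on that single precedent alone. Compound 4 is therefore estimated at 1800 nM, with a likely range from 900 nM to 3600 nM in this assay.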

Compound 4, half-maximal inhibitory concentration: 1370 nM
Compound 4: middle estimate off by 1.3-fold (0.12 log units), on the high side, and the stated range covers the measured number.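

In this assay, placing 3-hydroxy-4-methoxyphenyl in place of 4-hydroxy-3,5-dimethoxyphenyl on the core of compound 3 gives a 1.6-fold higher number from compound 3 to compound 4 (0.21 log units; within the scatter). Set beside the earlier step, the two results cannot be told apart: the same change on two cores in this assay, a 2.2-fold higher number (0.35 log units; beyond the scatter) from compound 1 to compound 2 and a 1.6-fold higher number (0.21 log units; within the scatter) from compound 3 to compound 4, 1.4-fold (0.14 log units) apart, within the scatter of two such steps. The two cores therefore give no sign that this change behaves differently from one to the other, but this rests on a single pair of steps in one assay, and because the second step alone lies within the scatter, it does not show a real effect on that core or a rule for other cores.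

The compounds shown leave open how a dimethylamino group or a carboxylic acid would compare with these two aryl substituents, on a double-bonded chain carbon bound to a double-bonded chain carbon. They also leave open whether the change would read the same on a core with outer aryl groups bearing something other than methoxy, such as chlorine or an amine.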